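A few compounds are considered here, and "the series" means these few. Any claim that something is new, unique, unknown or untested is made for them only; others in the source may bear on it.

Measured compounds:
compound 1 `CCn1nc(C)c2c1CCN(C(C(=O)NC)c1ccccc1)C2CCc1ccccc1F`, 22 nM;
compound 2 `CCn1nc(C)c2c1CCN([C@@H](C(=O)NC)c1ccccc1)[C@H]2CCc1ccc(C(F)(F)F)cc1`, 3 nM;
compound 3 `CCn1nc(C)c2c1CCN(C(C(=O)NC)c1ccccc1)C2CCc1ccc(OC)cc1`, 219 nM.

In a functional assay on CHO cells for antagonist activity at Orexin receptor type 2 (Homo sapiens), read by FLIPR and calcium flux (a lower number here means a stronger inhibitor, a higher number a weaker inhibitor), compound 2 stands lowest of the three, beyond the scatter against both compound 1 and compound 3, so it is the strongest inhibitor shown. For the measured compounds named here, the only single-point step within the measured set is a 10-fold higher number from compound 1 to compound 3 (1.00 log units; beyond the scatter), which shows that exchanging the aromatic group on the chain moves the read-out by a modest but clear margin.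

Compound 4 `CCn1nc(C)c2c1CCN([C@@H](C(=O)NC)c1ccccc1)[C@H]2COc1ccc(C)cc1` is not yet measured. It differs from compound 2 by 4-methylphenoxy in place of 4-(trifluoromethyl)benzyl on a saturated chain carbon bound to a saturated ring carbon. Going by the values given here, no measured pair shares this exact change: the chain is shortened, an oxygen enters, and the trifluoromethyl-bearing ring is replaced. The step from compound 1 to compound 3 is the closest guide and points to a loss when the aromatic end of the chain is altered. Compound 4 is therefore expected to give 30 nM in this assay, within 8 nM to 120 nM, meaning an estimated 10-fold higher number from compound 2 to compound 4 (1.00 log units; beyond the scatter).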

Compound 4, half-maximal inhibitory concentration: 19 nM
For compound 4 the middle estimate is 1.6-fold (0.20 log units) above the measured one, and the stated range covers the measured number.
By their numbers in this assay, from the lowest: compound 2; then compounds 4 and 1 (each within the scatter of the next); then compound 3.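

In this assay, the earlier step altered only the ring at the end of the chain, whereas this one also alters the link to the ring: 4-methylphenoxy in place of 4-(trifluoromethyl)benzyl gives a 6.3-fold higher number from compound 2 to compound 4 (0.80 log units; beyond the scatter). The position therefore accepts a group carrying an oxygen in the chain at a modest cost, with compound 2 keeping the lower number. Nothing available explains this step.

The oxygen and the change of ring substituent enter together, so their separate shares in the step stay unresolved; 4-(trifluoromethyl)phenoxy or 4-methylbenzyl at this position would separate them. From the compounds shown here alone, the response to a carboxylic acid or an amine on the terminal ring, or to a longer chain, also remains open.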